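Working notes: phenyl to fluoropyridyl on the chain carbon

A few compounds are considered here, and "the series" means these few. Any claim that something is new, unique, unknown or untested is made for them only; others in the source may bear on it.

In an ADME assay (liver) for metabolic stability, with Liver microsome (Rattus norvegicus) as the target, using microsomes (on this read-out lower numbers stand for slow clearance and higher numbers for fast clearance), compound 2 `c1ccc([C@H](Nc2nnc(-c3c[nH]c4ncccc34)o2)C2CC2)cc1` gives 31 mL.min-1.g-1. Of the two numbers in hand, compound 2 holds the lowest; the nearest is compound 1 `c1ccc(CNc2nnc(-c3c[nH]c4ncccc34)o2)cc1`, which gives 40 mL.min-1.g-1 in this assay, and the step of a 1.3-fold lower number from compound 1 to compound 2 (0.11 log units; within the scatter) stays within the scatter. Compound 3 `Fc1cnccc1[C@H](Nc1nnc(-c2c[nH]c3ncccc23)o1)C1CC1` is not yet measured. It differs from compound 2 in one place: 3-fluoropyridin-4-yl in place of phenyl on a saturated chain carbon bound to a nitrogen on an aromatic ring and a saturated ring carbon. For the measured compounds named here, no measured step bears on this change: the single step so far, a 1.3-fold lower number from compound 1 to compound 2 (0.11 log units; within the scatter), concerns a different position and did not itself reach beyond the scatter. On the numbers available, the expected step in this assay is therefore a 1.1-fold lower number from compound 2 to compound 3 (0.04 log units; within the scatter), with no direction that can be read as beyond the scatter. The estimate for compound 3 in this assay is 28 mL.min-1.g-1, with a range from 14 mL.min-1.g-1 to 56 mL.min-1.g-1.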

Compound 3, intrinsic clearance in microsomes: 45 mL.min-1.g-1
For compound 3 the middle estimate is 1.6-fold (0.21 log units) below the measured one, and the stated range covers the measured number.
By their numbers in this assay, from the lowest: compounds 2, 1 and 3 (each within the scatter of the next).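

In this assay, for the compounds shown here, the group on the saturated chain carbon bound to a nitrogen on an aromatic ring and a saturated ring carbon now has a measured step of its own, a 1.5-fold higher number from compound 2 to compound 3 (0.16 log units; within the scatter), which is the first reading at this position. Replacing phenyl with 3-fluoropyridin-4-yl brings a ring nitrogen, a fluorine and a hydrogen-bond acceptor into the group, yet compound 2 and compound 3 remain within the scatter of each other on this read-out. No supporting data are available to interpret this result. As far as these compounds go, whether an unfluorinated pyridin-4-yl, a 3-fluorophenyl or an aminomethyl-bearing phenyl at this position would give a step beyond the scatter remains open. The separate contributions of the ring nitrogen and the fluorine also remain unresolved, since the two enter together in compound 3.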